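This account rests on a few compounds, and the source may have more. Where it says the series, first, only, none or still open, it means among the compounds named here.

Compound 1 `CC(C)N(Cc1cccc(OCCCCCC(=O)O)c1)C(=O)c1ccc(-c2ccncc2)cc1` gives > 26000 nM in an ADME assay on Raji cells (Homo sapiens) for cytotoxicity, read by CellTiter-Glo and resazurin assay, with a stated time of 72 h (a lower number here means that less compound is needed, a higher number that more compound is needed for the effect), which is a limit of the assay and not a number.
Compound 2 `CC(C)N(Cc1cccc(OCCCCCC(=O)O)c1)C(=O)c1ccc(-c2cccc(Oc3ccccc3)c2)cc1` gives > 18700 nM in this assay, again only a limit.
Compound 3 `CCOC(=O)CCCCCOc1cccc(CN(C(=O)c2ccc(-c3ccncc3)cc2)C(C)C)c1` gives > 26000 nM in this assay, again only a limit.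

Compound 3 therefore has no place on a scale of numbers: in this assay it shows only a limit, and the two other values shown are limits as well. Going by the values given here, the single step that joins two measured compounds, a step that the two limits leave unreadable from compound 1 to compound 3, runs from one limit to another and cannot be read; what is known is the limit of > 26000 nM in this assay, at which 2 of the 3 values shown sit, for two of the three compounds and the limit of > 18700 nM in this assay, at which 1 of the 3 values shown sits, for the third.

Compound 4 `CCOC(=O)CCCCCOc1cccc(CN(C(=O)c2ccc(-c3cccc(O)c3)cc2)C(C)C)c1` differs from compound 3 in one place: 3-hydroxyphenyl in place of pyridin-4-yl on an aromatic carbon. Among the compounds with values here, no measured step bears on this change, and the unreadable step from compound 1 to compound 3 gives no size to lean on. With every shown value sitting at a limit, there is nothing that points toward a move in either direction beyond the scatter.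

Compound 4 is accordingly expected to give about 30000 nM in this assay, within 8000 nM to 100000 nM, and most probably to be reported again as a limit rather than a number. The step this expectation implies is a step that the limit leaves unreadable from compound 3 to compound 4.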

Compound 4, half-maximal effective concentration: > 26000 nM
Compound 4: no number, only a limit (the forecaster's own chance of this, stated with the estimate: 80%); the middle value does not contradict the limit.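

In this assay compound 4 gives > 26000 nM, which is a limit of the assay and not a number. Going by these compounds alone, compound 3 gives > 26000 nM, again only a limit, so no step from compound 3 to compound 4 can be read. The compounds shown leave open at what concentration any of them reaches the half-maximal effect, and whether 3-hydroxyphenyl in place of pyridin-4-yl changes that concentration.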